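From compound 2 to compound 4: a methoxy added

This account rests on a few compounds, and the source may have more. Where it says the series, first, only, none or still open, it means among the compounds named here.

Three compounds measured in a toxicity assay on HEK-293T cells (Homo sapiens) for inhibition, read by MTT assay, with a stated time of 24 h (on this read-out lower numbers stand for higher toxicity in this test and higher numbers for lower toxicity in this test), gave these values, all of them limits of the assay and not numbers:

compound 1 (`COc1cccc(N2CCN(c3c(CO)c(=O)oc4ccccc34)CC2)c1`): > 50000 nM
compound 2 (`O=c1oc2ccccc2c(N2CCN(c3ccccc3)CC2)c1CO`): > 50000 nM
compound 3 (`O=c1oc2ccccc2c(N2CCN(C(c3ccccc3)c3ccc(Cl)cc3)CC2)c1CO`): > 50000 nM

Compound 2 reports only the limit > 50000 nM and no number. The other two measured values are limits too, so the three compounds cannot be ranked. Compound 4 (`COc1ccccc1N1CCN(c2c(CO)c(=O)oc3ccccc23)CC1`) is compound 2 changed as follows: methoxy in place of hydrogen on an aromatic carbon and so it carries methoxy in place of hydrogen on an aromatic carbon, ortho to a large group.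

Going by the values given here, the one measured step of this kind is a step that the two limits leave unreadable from compound 1 to compound 2 and it swaps the same two groups, so in this assay no step beyond the scatter is expected, in either direction. The whole set offers only the limit of > 50000 nM in this assay, at which 3 of the 3 values shown sit, and no readable size. The estimated step is a number no higher from compound 2 to compound 4 (the limit leaves the size open) and it has no readable direction. For compound 4 the estimate is 50000 nM with an expected range from 25000 nM to 100000 nM and a report as a limit is likely.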

Compound 4, half-maximal cytotoxic concentration: > 50000 nM
Compound 4: only a limit was reported (the forecaster's own chance of this, stated with the estimate: 85%); the middle value sits exactly at the limit.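

Compound 4 gives only a limit, as do compound 1 and compound 2, so no step among these three compounds can be read: the limit of > 50000 nM in this assay, at which 4 of the 4 values shown sit.

Going by these compounds, whether adding a methoxy, or moving it from 3-methoxyphenyl to 2-methoxyphenyl, changes the result in this assay stays open.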